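Chloro for methyl on the sulfonyl ring

The compounds below may be only part of what the source reports. "The series", "measured", "known", "first", "only" and "open" are said of these compounds alone.

Among the compounds with values here, in an ADME assay on HEK-293T cells (Homo sapiens) for inhibition, read by CCK-8 assay, with a stated time of 48 h, tested at 20 uM (a lower number here means less inhibition of growth, a higher number more inhibition of growth at the concentration tested), compound 1 `COc1ccc(Cc2nnc(NC(=O)/C(C#N)=C/c3ccccc3OS(=O)(=O)c3ccc(C)cc3)s2)cc1` gives 21% and compound 2 `Cc1ccc(S(=O)(=O)Oc2ccccc2/C=C(\C#N)C(=O)Nc2nnc(Cc3cccc4ccccc34)s2)cc1` gives 23%, so compound 2 stands level with the only other measured compound. Compound 3 `N#C/C(=C\c1ccccc1OS(=O)(=O)c1ccc(Cl)cc1)C(=O)Nc1nnc(Cc2cccc3ccccc23)s1` has chloro in place of methyl on an aromatic carbon, para to a large group: chloro in place of methyl on an aromatic carbon. Within the data shown here, the sole measured step, a number 2 percentage points higher from compound 1 to compound 2 (within the scatter), has naphthalen-1-yl in place of 4-methoxyphenyl, so it arose at another place and only loosely bears on this change. No shift beyond the scatter is therefore expected in this assay. The expected step is a number 1 percentage points higher from compound 2 to compound 3 (within the scatter). Compound 3 is estimated at 24%, within a range of 10% to 40%.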

Compound 3, percent growth inhibition at one concentration: 16%
Compound 3: middle estimate off by 8 percentage points, on the high side; low and high end bracket the measured number.
By their numbers in this assay, from the lowest: compounds 3, 1 and 2 (each within the scatter of the next).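

In this assay, within the data shown here, chloro in place of methyl on an aromatic carbon, para to a large group, gives a number 7 percentage points lower from compound 2 to compound 3 (within the scatter) and is the first step read at this position rather than on the naphthalen-1-yl side. A change at this position thus stays within the scatter for this one pair, just as the earlier step elsewhere did. Nothing available accounts for the step. On these data alone, whether an amine or a carboxylic acid at this position would give a step beyond the scatter remains open. So does whether chloro would read alike with 4-methoxyphenyl in place of naphthalen-1-yl.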